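This account rests on a few compounds, and the source may have more. Where it says the series, first, only, none or still open, it means among the compounds named here.

Measured compounds:
compound 1, `C/C=C\C(=O)Nc1cc(Nc2nc3c(c(-c4cn(C)c5ccccc45)n2)CSCC3)c(OC)cc1N(C)CCN(C)C`, 6860 nM in a functional assay on A549 cells (Homo sapiens) for inhibition, read by MTT assay, with a stated time of 72 h; a higher number here means a weaker inhibitor, a lower number a stronger inhibitor
compound 2, `CC/C=C\C(=O)Nc1cc(Nc2nc3c(c(-c4cn(C)c5ccccc45)n2)CSCC3)c(OC)cc1N(C)CCN(C)C`, 236 nM
compound 3, `C/C=C\C(=O)Nc1cc(Nc2nc3c(c(-c4cn(C)c5ccccc45)n2)CS(=O)(=O)CC3)c(OC)cc1N(C)CCN(C)C`, 4260 nM

The change from compound 1 to compound 2, (methyl in place of hydrogen on a saturated chain carbon bound to a double-bonded chain carbon), gave a 29-fold lower number from compound 1 to compound 2 (1.46 log units; beyond the scatter). Compound 3 carries a different core from compound 1; the difference between the two cores is not broken down here, and compound 3 with 4260 nM sits within the scatter of compound 1. Compound 4, `CC/C=C\C(=O)Nc1cc(Nc2nc3c(c(-c4cn(C)c5ccccc45)n2)CS(=O)(=O)CC3)c(OC)cc1N(C)CCN(C)C`, is still to be measured; it differs from compound 3 by methyl in place of hydrogen on a saturated chain carbon bound to a double-bonded chain carbon, the same change that was made from compound 1 to compound 2. Because that step gave a 29-fold lower number from compound 1 to compound 2 (1.46 log units; beyond the scatter), the step from compound 3 to compound 4 is expected to be a 14-fold lower number from compound 3 to compound 4 (1.15 log units; beyond the scatter), somewhat tempered since it rests on one pair only. Compound 4 is thus estimated at 300 nM, between 80 nM and 1500 nM.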

Compound 4, half-maximal inhibitory concentration: 1350 nM
Estimate against measurement, compound 4: 4.5-fold (0.65 log units) below; the measured number falls inside the stated range.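

The change of methyl in place of hydrogen on a saturated chain carbon bound to a double-bonded chain carbon again lowered the number in this assay, giving a 3.2-fold lower number from compound 3 to compound 4 (0.50 log units; beyond the scatter), so the direction of the step held on the core of compound 3. The size of the step did not hold, and the two steps are clearly apart: the same change on two cores in this assay, a 29-fold lower number (1.46 log units; beyond the scatter) from compound 1 to compound 2 and a 3.2-fold lower number (0.50 log units; beyond the scatter) from compound 3 to compound 4, 9.2-fold (0.96 log units) apart, beyond the scatter of two such steps. These two pairs show that the size of this step depends on the core, but they do not show which feature of the cores accounts for the gap or how the step would behave on a third core.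

The compounds shown leave open whether a longer chain in place of the but-1-en-1-yl group would lower the number further on either core. They also leave open how a branched group such as isopropyl would fare there.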